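Working notes: a larger group in place of methoxy

This account rests on a few compounds, and the source may have more. Where it says the series, first, only, none or still open, it means among the compounds named here.

Values so far in a functional assay on SK-OV-3 cells (Homo sapiens) for antiproliferative activity, read by MTT assay, with a stated time of 72 h (a lower number here means a stronger inhibitor, a higher number a weaker inhibitor), are these
- compound 1 `O=C(CCc1cccc2c1B(O)OC2)Nc1ccccc1` gives 200 nM
- compound 2 `CC(C)(C)c1ccc(NC(=O)CCc2cccc3c2B(O)OC3)cc1` gives 4200 nM
- compound 3 `COc1ccc(NC(=O)CCc2cccc3c2B(O)OC3)cc1` gives 900 nM

Compound 3 (900 nM) holds the second highest of the three numbers. Two steps of similar size, a 4.5-fold higher number from compound 1 to compound 3 (0.65 log units; beyond the scatter) and a 4.7-fold lower number from compound 2 to compound 3 (0.67 log units; beyond the scatter) set it apart from the other two compounds.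

Compound 4 `CC(C)(C)OC(=O)NCc1ccc(NC(=O)CCc2cccc3c2B(O)OC3)cc1` carries ((tert-butoxycarbonyl)amino)methyl in place of methoxy on an aromatic carbon, para to a large group (((tert-butoxycarbonyl)amino)methyl in place of methoxy on an aromatic carbon). The measured steps that bear on this change are a 4.5-fold higher number from compound 1 to compound 3 (0.65 log units; beyond the scatter) and the large 21-fold higher number from compound 1 to compound 2 (1.32 log units; beyond the scatter) in which hydrogen gives way to tert-butyl. Among these three compounds, both replacements of hydrogen gave a higher number, and none goes against that. Among the compounds with values here, no measured compound carries a group of the kind entering here, so the reading across is uncertain and the range must stay wide.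

A modest move towards a higher number is expected, and the estimated step is a 2.8-fold higher number from compound 3 to compound 4 (0.44 log units; beyond the scatter) in this assay on this reasoning. Compound 4 is estimated at 2500 nM with an expected range of 800 nM to 8000 nM as the working figure.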

Compound 4, half-maximal inhibitory concentration: 2000 nM
The estimate for compound 4 lay 1.3-fold (0.10 log units) above the measured number; measured number inside the range.
By their numbers in this assay, from the lowest: compound 1; then compound 3; then compound 4; then compound 2.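

In this assay, ((tert-butoxycarbonyl)amino)methyl gives a 2.2-fold higher number from compound 3 to compound 4 (0.35 log units; beyond the scatter) and a 2.1-fold lower number from compound 2 to compound 4 (0.32 log units; beyond the scatter), so a group of 9 heavy atoms, with a hydrogen-bond donor that methoxy lacks, places compound 4 between the methoxy and tert-butyl compounds. Against the unsubstituted compound there is a 10-fold higher number from compound 1 to compound 4 (1.00 log units; beyond the scatter), which makes this the third replacement of hydrogen at this position to give a higher number, with none among the four compounds going against that; the order does not simply follow the size of the entering group, however, as compound 2 keeps the highest number of the four. No data are available here to explain this order.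

The compounds shown leave open where a free aminomethyl group or a carboxylic acid at this position would stand relative to compound 1, and so whether any replacement of hydrogen here can reach the number of compound 1. They also leave open whether a single fluorine or a methyl group, both smaller than the groups compared here, would give a step beyond the usual scatter.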